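A few compounds are considered here, and "the series" means these few. Any claim that something is new, unique, unknown or untested is made for them only; others in the source may bear on it.

In an assay on isolated protein for inhibition of protein arginine N-methyltransferase 6 (Homo sapiens) (a lower number here means a stronger inhibitor, a higher number a weaker inhibitor), compound 1 `C[C@H](N)C(=O)NCc1cccnc1Oc1ccc(F)cc1F` gives 14000 nM. Of the two compounds that yield a number in this assay it has the higher one, yet compound 2 `CNCCNC1CCN(c2cccc(-c3ccnc(C)n3)c2)CC1` gives 8900 nM, and the gap between compound 1 and compound 2 lies within the usual scatter. Compound 3 `Cc1cc(OCCNCCN)ccc1C(C)C` is reported in this assay as "not active" (no number reported), without a number. Compound 4 `CNCC(=O)NCc1cccnc1Oc1ccc(F)cc1F` differs from compound 1 by a single rearrangement, ((methylamino)methyl in place of 1-aminoethyl on a carbonyl carbon), so the two share every atom and the same core. For the measured compounds named here, no measured pair shows such a change, so no step size is known for it. The step from compound 1 to compound 4 is expected to be small, at most modestly towards a weaker inhibitor, a 1.4-fold higher number from compound 1 to compound 4 (0.15 log units; within the scatter). Compound 4 is therefore estimated at 20000 nM, within 7000 nM to 60000 nM.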

Compound 4, half-maximal inhibitory concentration: "not active" (no number reported)
Compound 4 has no reported number here, and the estimate cannot be compared.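

In this assay, for the compounds shown here, compound 4 has no number, so no step from compound 1 to compound 4 can be read. Nothing shown here accounts for this result. Open remains how far (methylamino)methyl in place of 1-aminoethyl shifts inhibition.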